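The source may report more compounds than this note shows. Statements on the series, on what has been measured and on what is new or still open speak of the compounds shown alone.

Going by the values given here, in a functional assay on MCF7 cells (Homo sapiens) for cytotoxicity, read by MTT assay, with a stated time of 48 h (on this read-out higher numbers stand for weaker inhibition and lower numbers for stronger inhibition), only two compounds sharing one core have been measured so far. Compound 1 `Fc1cccc(-c2nc(Nc3ccc(Cl)cc3)c3cc(F)ccc3n2)c1` gives > 50000 nM, which is a limit of the assay and not a number. Compound 2 `Fc1cccc(-c2nc(Nc3ccc(Br)cc3)c3cc(F)ccc3n2)c1` gives > 50000 nM, which is also a limit. The record so far is the limit of > 50000 nM in this assay, at which 2 of the 2 values shown sit, so compound 2 has no number of its own to start from. Among the compounds with values here, the only measured step is a step that the two limits leave unreadable from compound 1 to compound 2, and it offers no size to carry forward.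

Compound 3 `Oc1cccc(Nc2nc(-c3cccc(F)c3)nc3ccc(F)cc23)c1` has not yet been measured. Its change from compound 2 is a single one, with 3-hydroxyphenyl in place of 4-bromophenyl on a nitrogen on an aromatic ring. The two halogen-bearing compounds give no guide to what this different group will do, so the expectation is a cautious one. The expected step, an at least 1.4-fold lower number from compound 2 to compound 3 (0.15 log units; that floor lies within the scatter), is estimated as a modest move towards stronger inhibition, and a result at the same limit would be no surprise. For compound 3 the estimate is 35000 nM, with an expected range of 8000 nM to 50000 nM.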

Compound 3, half-maximal inhibitory concentration: > 50000 nM
Compound 3: a limit, no number; the forecaster's own chance of this, stated with the estimate: 50%; middle value at least 1.4-fold (0.15 log units) away from the limit.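

In this assay compound 3 gives > 50000 nM, which is a limit and not a number. The steps to compound 3 from compound 1 and from compound 2 therefore cannot be read: the limit of > 50000 nM in this assay, at which 3 of the 3 values shown sit.

Still open, from the compounds shown here alone, is how compound 1, compound 2 and compound 3 compare with one another, and whether any change on the shared core gives a true number in this assay.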